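Naphthyl in Place of Methoxyphenyl on the Pyrazoline Core

This account rests on a few compounds, and the source may have more. Where it says the series, first, only, none or still open, it means among the compounds named here.

Of the compounds shown here, two from this series have been measured. Compound 1 `COc1cc(C2CC(c3cc(OC)c(OC)c(OC)c3)=NN2C(C)=O)ccc1OCc1cn(Cc2ccc([N+](=O)[O-])cc2)nn1` gives 85% in a functional assay on A549 cells (Homo sapiens) for inhibition, read by sulforhodamine B assay, tested at 100 uM; on this read-out lower numbers stand for less inhibition of growth and higher numbers for more inhibition of growth at the one concentration tested. Compound 2 `COc1ccc(C2=NN(C(C)=O)C(c3ccc(OCc4cn(Cc5ccc([N+](=O)[O-])cc5)nn4)c(OC)c3)C2)cc1` gives 84% in this assay. Going by the values given here, the only measured step is a number 1 percentage points lower from compound 1 to compound 2 (within the scatter), so the two aryl groups on the carbon with a double bond to nitrogen gave indistinguishable results. Compound 2 thus stands at the lower of the two numbers, but its distance to compound 1 lies within the scatter. Compound 3 `COc1cc(C2CC(c3cccc4ccccc34)=NN2C(C)=O)ccc1OCc1cn(Cc2ccc([N+](=O)[O-])cc2)nn1` has not been measured. It differs from compound 2 by naphthalen-1-yl in place of 4-methoxyphenyl on a carbon with a double bond to nitrogen. Among the compounds with values here, the single measured step bears on this change only loosely, since it exchanged one substituted phenyl for another without a shift beyond the scatter. Compound 3 is therefore expected to come out near compound 2, and the estimated step is a number 4 percentage points lower from compound 2 to compound 3 (within the scatter). The estimate for compound 3 is 80%, ranging from 60% to 95%.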

Compound 3, percent growth inhibition at one concentration: 95%
Beside the measured number, compound 3's estimate is 15 percentage points below it; the measured number falls inside the stated range.
By their numbers in this assay, from the lowest: compounds 2, 1 and 3 (each within the scatter of the next, the first and the last beyond it).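

Going by these compounds alone, the carbon with a double bond to nitrogen, where the first step between aryl groups stayed within the scatter, proves able to register a change in this assay: naphthalen-1-yl in place of 4-methoxyphenyl gives a number 11 percentage points higher from compound 2 to compound 3 (beyond the scatter) and is the first step to pass the scatter, though only modestly. The same group in place of 3,4,5-trimethoxyphenyl gives a number 10 percentage points higher from compound 1 to compound 3 (within the scatter) and so cannot be told apart from that substituted phenyl. The gain therefore holds against one phenyl partner only, and the three aryl groups fall into no clear order.

Going by these compounds, whether the second aromatic ring or the loss of the methoxy group matters more stays open, as does the outcome with naphthalen-2-yl, cyclohexyl or an aminophenyl group at this place. Nothing available here explains the step.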